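Methyl on the core: from compound 1 to compound 3

A few compounds are considered here, and "the series" means these few. Any claim that something is new, unique, unknown or untested is made for them only; others in the source may bear on it.

Measured so far:
compound 1, `C[C@H](Nc1nc(N)nc(N)c1C#N)c1cc2ccc(F)cn2c(=O)c1-c1ccccc1`; in an ADME assay on the whole organism (Mus musculus, strain BALB/C) for pharmacokinetics, read by LC-MS, with a stated time of 24 h, at a dose of 10 mg/kg by the oral route (a lower number here means less compound in the circulation, a higher number more compound in the circulation at the dose given), compound 1 gives 2600 nM
compound 2, `C[C@H](Nc1nc(N)nc(N)c1C#N)c1cc(=O)n2cc(F)ccc2c1-c1cc(F)cc(F)c1`; in this assay compound 2 gives 4700 nM

Compound 1 stands lowest of the two numbers, and the nearest number is that of compound 2; the two values lie within the scatter of each other, so no order between them is claimed and neither is called the higher of the pair.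

Compound 3, `Cc1c([C@H](C)Nc2nc(N)nc(N)c2C#N)c(-c2ccccc2)c(=O)n2cc(F)ccc12`, has not been measured in this assay. It differs from compound 1 in one place: methyl in place of hydrogen on an aromatic carbon of the shared core. Within the data shown here, no pair of measured compounds shows this change, so there is no measured step to lean on. With only the values of compound 1 and compound 2 in hand, a step of no more than the scatter is expected, in no particular direction.

Compound 3 is expected to give 2600 nM in this assay, with a range of 900 nM to 7500 nM. This estimate means an expected step of no change at the digits printed from compound 1 to compound 3 (within the scatter), inside the scatter.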

Compound 3, maximal plasma concentration: 2100 nM
The estimate for compound 3 lay 1.2-fold (0.09 log units) above the measured number; low and high end bracket the measured number.
By their numbers in this assay, from the lowest: compounds 3, 1 and 2 (each within the scatter of the next, the first and the last beyond it).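

In this assay the series now has its first measured single-place step, a 1.2-fold lower number from compound 1 to compound 3 (0.09 log units; within the scatter), and it gives a direct reading for methyl in place of hydrogen on an aromatic carbon of the shared core. At this position, ortho to a large group and meta to a phenyl group, the added methyl leaves the maximal plasma concentration within the scatter of the parent, so this one carbon carries no readable effect on this read-out for the compound with the unsubstituted phenyl group. No measurement at hand bears on the reason for this result.

From the compounds shown here alone, the reading covers methyl alone, so it remains open whether ethyl, methoxy, an amine or a carboxylic acid on the same aromatic carbon would also stay within the scatter of compound 1. Going by these compounds, it also remains open whether methyl at this kind of position gives a step of similar size when the phenyl group carries fluorine atoms, and whether the maximal plasma concentration alone tells the whole of the exposure.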